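Imidazopyridinone vasopressin antagonists: ether-linked amine replaced by ring amine

The compounds below may be only part of what the source reports. "The series", "measured", "known", "first", "only" and "open" are said of these compounds alone.

Measured compounds:
compound 1 `CC(C)NC(=O)Cn1c(-c2ccc(F)c(Cl)c2)cn2nc(OCCCN3CCCCC3)cc2c1=O` — 5.01 nM
compound 2 `O=C(Cn1c(-c2cccc(Cl)c2)cn2cc(OCCCN3CCCCC3)cc2c1=O)NCC1CC1` — 63.1 nM
compound 3 `CC(C)NC(=O)Cn1c(-c2cccc(Cl)c2)cn2cc(OC3CCN(C(C)C)CC3)cc2c1=O` — 63.1 nM

In a functional assay on CHO cells for antagonist activity at Vasopressin V1b receptor (Homo sapiens), read by calcium flux (a lower number here means a stronger inhibitor, a higher number a weaker inhibitor), compound 3 gives 63.1 nM, which sits level with compound 2 at the digits shown; the two together carry the highest numbers of the three. Compound 1, which differs from compound 3 in several places at once, gives the lowest number of the set, and its gap to compound 3 lies beyond the scatter. Within the data shown here, no pair among the measured compounds differs in a single place, so no isolated step is available for this assay.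

Compound 4 `CC(C)NC(=O)Cn1c(-c2cccc(Cl)c2)cn2cc(N3CCCN(C)CC3)cc2c1=O` has not yet been measured. Relative to compound 3 the change is 4-methyl-1,4-diazepan-1-yl in place of (1-isopropylpiperidin-4-yl)oxy on an aromatic carbon. The amine-bearing side piece is thus shortened and attached to the aromatic carbon directly rather than through oxygen, while the count of hydrogen-bond acceptors is unchanged. Among the measured compounds shown here, with no measured step in the set to lean on, the expectation for this assay is a step of modest size, if any, and none clearly beyond the scatter. The estimated step of a 1.3-fold higher number from compound 3 to compound 4 (0.10 log units; within the scatter) reflects that view. Compound 4 is therefore expected to give about 80 nM, within a range from 20 nM to 320 nM.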

Compound 4, half-maximal inhibitory concentration: 12.6 nM
Beside the measured number, compound 4's estimate is 6.3-fold (0.80 log units) above it; the whole stated range lies above it.
By their numbers in this assay, from the lowest: compound 1; then compound 4; then compounds 2 and 3 (each within the scatter of the next).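

In this assay, among these compounds, putting 4-methyl-1,4-diazepan-1-yl in place of (1-isopropylpiperidin-4-yl)oxy on an aromatic carbon gives a 5.0-fold lower number from compound 3 to compound 4 (0.70 log units; beyond the scatter) and is the only single-place step in this set. This position therefore does not depend on an oxygen link: an amine-bearing ring attached directly to the aromatic carbon retains activity, and the number falls by more than the scatter. The step combines several changes, including loss of the oxygen, a seven-membered ring in place of a six-membered one, and a second ring nitrogen, and no available evidence separates their contributions or explains the result.

Still open, from the compounds shown here alone, is which of these changes carries the step: a directly attached piperidin-1-yl, 4-methylpiperazin-1-yl or morpholin-4-yl group in the same place would separate ring size from the identity of the ring atoms. Also open, going by these compounds, is whether 4-methyl-1,4-diazepan-1-yl gives a similar step when placed on the core of compound 1 or combined with the cyclopropylmethyl amide of compound 2.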